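Aryl urea terminus on the hydrazide linker of compound 2

This account rests on a few compounds, and the source may have more. Where it says the series, first, only, none or still open, it means among the compounds named here.

Compound 1 `O=C1NCCN1C(c1ccccc1)(c1ccccc1)c1ccccc1` gives 102000 nM in a functional assay on HeLa cells (Homo sapiens) for inhibition, read by MTT assay, with a stated time of 4 days (a higher number here means a weaker inhibitor, a lower number a stronger inhibitor), and serves as a weak reference point. Compound 2 `COc1cc(NC(C)CCCNC(=O)NNC(=O)N(CCO)CCO)c2ncccc2c1` reaches only > 250000 nM in this assay, which is a limit of the measurement and not a number. Going by the values given here, compound 3 `COc1cc(NC(C)CCCNC(=O)Nc2ccc(Cl)c(C(F)(F)F)c2)c2ncccc2c1`, in which the whole terminal group is exchanged, gives 3900 nM, and the step of an at least 64-fold lower number from compound 2 to compound 3 (1.80 log units; beyond the scatter) is the only measured step; it is large, but because compound 2 sits at the limit of > 250000 nM in this assay, at which 1 of the 3 values shown sits, its true size is open upwards.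

Compound 4 `COc1cc(NC(C)CCCNC(=O)NNC(=O)Nc2ccc(Cl)c(C(F)(F)F)c2)c2ncccc2c1` is the third member. It differs from compound 2 by (4-chloro-3-(trifluoromethyl)phenyl)amino in place of bis(2-hydroxyethyl)amino on a carbonyl carbon; the carbonyl that carries the new group still sits on the amide-type nitrogen of the hydrazide link, so compound 4 keeps the longer connecting chain of compound 2 while taking on the aryl terminus of compound 3. The step from compound 2 to compound 3 therefore bears on it directly, and a drop in the number is expected, though the retained hydrazide link leaves it uncertain whether compound 4 comes down as far as compound 3. Compound 4 is estimated at 30000 nM, with a range from 6000 nM to 150000 nM. The step of an at least 8.3-fold lower number from compound 2 to compound 4 (0.92 log units; beyond the scatter) is the expected size of that change.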

Compound 4, half-maximal inhibitory concentration: 17000 nM
The estimate for compound 4 lay 1.8-fold (0.25 log units) above the measured number; low and high end bracket the measured number.
By their numbers in this assay, from the lowest: compound 3; then compound 4; then compound 1. At a limit, above all of these: compound 2.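

In this assay, the step of an at least 14-fold lower number from compound 2 to compound 4 (1.16 log units; beyond the scatter) shows that the number falls even with the hydrazide link kept, so the drop seen earlier does not depend on losing that link. The earlier step exchanged the link and the terminus together, whereas this one changes a single group on a carbonyl carbon whose other neighbour is an amide-type nitrogen: (4-chloro-3-(trifluoromethyl)phenyl)amino in place of bis(2-hydroxyethyl)amino. Compound 2 stands at a limit and not at a number, so the true size of this step stays open upwards: the limit of > 250000 nM in this assay, at which 1 of the 4 values shown sits.

What the hydrazide link itself contributes stays unsized, since compound 3 at 3900 nM and compound 4 at 17000 nM are two printed values with no listed step between them. Also open, as far as these compounds go, is which part of the entering group carries the change, which a plain phenylamino terminus, a 4-chlorophenylamino terminus or a 3-(trifluoromethyl)phenylamino terminus on the same hydrazide link would separate, and whether a longer chain in the link would move the number at all.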